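From phenyl to 4-chlorophenyl on a shared core

A few compounds are considered here, and "the series" means these few. Any claim that something is new, unique, unknown or untested is made for them only; others in the source may bear on it.

In an ADME assay on HepG2 cells (Homo sapiens) for cytotoxicity, read by MTT assay, with a stated time of 24 h (on this read-out higher numbers stand for lower toxicity in this test and lower numbers for higher toxicity in this test), compound 3 `CC(C)=CCC1=C(OCc2cn(-c3ccccc3)nn2)C(=O)c2ccccc2C1=O` gives 100000 nM, the lowest of three numbers. Compound 2 `CC(C)=CCC1=C(OCc2cn(C3CCNCC3)nn2)C(=O)c2ccccc2C1=O` gives 570000 nM, and compound 1 `CC(C)=CCC1=C(OCc2cn(-c3ccnc4cc(Cl)ccc34)nn2)C(=O)c2ccccc2C1=O` gives 1940000 nM. Compound 4 `CC(C)=CCC1=C(OCc2cn(-c3ccc(Cl)cc3)nn2)C(=O)c2ccccc2C1=O` has chloro in place of hydrogen on an aromatic carbon of that phenyl: chloro in place of hydrogen on an aromatic carbon. Among the compounds with values here, two measured steps bear on this, a 5.7-fold lower number from compound 2 to compound 3 (0.76 log units; beyond the scatter) and a 19-fold lower number from compound 1 to compound 3 (1.29 log units; beyond the scatter). Each swaps a whole group on an aromatic nitrogen, so neither measures this change directly. Only the group in compound 1 also carries chloro, which hints weakly at an upward move in this assay. The expected move is small and stays within the scatter: a 1.5-fold higher number from compound 3 to compound 4 (0.18 log units; within the scatter). Compound 4 is estimated at 150000 nM, with a range of 40000 nM to 500000 nM.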

Compound 4, half-maximal cytotoxic concentration: 1150000 nM
For compound 4 the middle estimate is 7.7-fold (0.88 log units) below the measured one; the measured number lies above the stated range.
By their numbers in this assay, from the lowest: compound 3; then compounds 2, 4 and 1 (each within the scatter of the next, the first and the last beyond it).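

In this assay one chloro on the phenyl ring, para to a large group, gives a 12-fold higher number from compound 3 to compound 4 (1.06 log units; beyond the scatter) and so shows that this single atom can move the number by a large step, which the whole-group swaps could not isolate. With a 2.0-fold higher number from compound 2 to compound 4 (0.30 log units; within the scatter) and a 1.7-fold lower number from compound 1 to compound 4 (0.23 log units; within the scatter) as the other two steps, 4-chlorophenyl stands level with piperidin-4-yl and 7-chloroquinolin-4-yl. Nothing measured here gives a reason for this jump. On these data alone, whether fluoro, methyl or methoxy at this place would move the number as chloro does stays open, as does the effect of chloro elsewhere on the phenyl ring.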